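The compounds below may be only part of what the source reports. "The series", "measured", "known", "first", "only" and "open" are said of these compounds alone.

Notes on the series. Compound 1 `N#Cc1cnc(NCc2cnccc2C(F)(F)F)cc1N[C@H]1CC[C@@H](O)CC1` gives 4500 nM in an assay on isolated protein for inhibition of protein kinase C delta type (Homo sapiens), read by TR-FRET, with a stated time of 2 h (on this read-out lower numbers stand for stronger inhibition and higher numbers for weaker inhibition), the highest number of the two measured. Compound 2 `CC1(C)C[C@H](Nc2cc(NCc3cnccc3C(F)(F)F)ncc2C#N)CC(C)(C)[C@@H]1O` gives 700 nM in this assay, a lower number, and that gap lies beyond the scatter. Compound 3 `CC1(C)C[C@H](Nc2cc(NCc3cnccc3C(F)(F)F)ncc2C#N)CC[C@H]1O` is not yet measured in this assay. Relative to compound 1 the change is 4-hydroxy-3,3-dimethylcyclohexyl in place of 4-hydroxycyclohexyl on a nitrogen on an aromatic ring. Within the data shown here, no single-change step between measured compounds exists, so the expectation rests only on the two values shown. A modest move toward a lower number is expected, roughly a 3.0-fold lower number from compound 1 to compound 3 (0.48 log units; beyond the scatter). Compound 3 is therefore estimated at 1500 nM in this assay, within 600 nM to 4000 nM.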

Compound 3, half-maximal inhibitory concentration: 2200 nM
The estimate for compound 3 lay 1.5-fold (0.17 log units) below the measured number, within the range that was stated.
By their numbers in this assay, from the lowest: compound 2; then compound 3; then compound 1.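

In this assay, among these compounds, 4-hydroxy-3,3-dimethylcyclohexyl in place of 4-hydroxycyclohexyl on a nitrogen on an aromatic ring gives a 2.0-fold lower number from compound 1 to compound 3 (0.31 log units; beyond the scatter), the first comparison that isolates a change at this position. The step is modest, and the larger group brings no loss here. No available evidence bears on the origin of this step.

From the compounds shown here alone, whether an amine in place of the hydroxy group would shift the number stays open. So does the effect of a cycloheptyl ring on the same nitrogen.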